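This account rests on a few compounds, and the source may have more. Where it says the series, first, only, none or still open, it means among the compounds named here.

Working notes on the series. In a functional assay on CCRF-CEM cells (Homo sapiens) for cytotoxicity, in the absence of a further agent (on this read-out lower numbers stand for stronger inhibition and higher numbers for weaker inhibition), compound 1 `Nc1nc(N)c(CCCN(Cc2ccc(NC(CCC(=O)O)C(=O)O)cc2)c2cc(F)c([N+](=O)[O-])cc2[N+](=O)[O-])c(O)n1` gives 40000 nM. In this assay, compound 2 `Nc1nc(N)c(CCCNc2cc(F)cc(F)c2[N+](=O)[O-])c(O)n1` gives 97000 nM. Compound 3 `Nc1nc(N)c(CCCN(Cc2ccc(NC(CCC(=O)O)C(=O)O)cc2)c2ccc([N+](=O)[O-])c(F)c2F)c(O)n1` returns only a limit, > 100000 nM, and it is the one limit among the three measured compounds.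

Compound 4 `Nc1nc(N)c(CCCN(Cc2ccc(NC(CCC(=O)O)C(=O)O)cc2)c2cc(F)ccc2[N+](=O)[O-])c(O)n1` has not yet been measured. It differs from compound 3 by a single exchange on an amine nitrogen: 5-fluoro-2-nitrophenyl in place of 2,3-difluoro-4-nitrophenyl (5-fluoro-2-nitrophenyl in place of 2,3-difluoro-4-nitrophenyl on an amine nitrogen).

Within the data shown here, no pair of measured compounds isolates this exchange, so the size of the step can only be judged from the values themselves. The remaining substituent on that nitrogen in compound 3 is also carried by compound 1, which still gives a number, 40000 nM, so compound 4 may plausibly give a reading within the range of this assay. The expected move is modest and toward stronger inhibition, estimated as an at least 1.6-fold lower number from compound 3 to compound 4 (0.22 log units; that floor lies within the scatter). A further reading at the limit of this assay would not be a surprise. Compound 4 is expected at 60000 nM, with an estimated range from 25000 nM to 100000 nM.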

Compound 4, half-maximal inhibitory concentration: > 100000 nM
Compound 4: only a limit was reported (the forecaster's own chance of this, stated with the estimate: 35%); middle value at least 1.6-fold (0.22 log units) away from the limit.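

In this assay, the series now has its first readable step: hydrogen in place of nitro on an aromatic carbon gives an at least 2.5-fold higher number from compound 1 to compound 4 (0.39 log units; beyond the scatter), so the loss of this nitro group weakens the read-out by more than the usual scatter. Among the compounds that share the remaining substituent on the amine nitrogen, compound 1, with two nitro groups on its aromatic ring, is so far the only one to give a number rather than a limit. The exchange of 2,3-difluoro-4-nitrophenyl for 5-fluoro-2-nitrophenyl on that amine nitrogen cannot be read, because compound 3 and compound 4 both stop at the limit of the assay: the limit of > 100000 nM in this assay, at which 2 of the 4 values shown sit.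

Going by these compounds, how far compound 4 and compound 3 lie past that limit stays unknown, so no order can be set between the two fluorinated nitrophenyl groups. On these data alone, it also stays open whether a nitrile, a chlorine or an amine in place of the lost nitro group would bring the read-out back within range, and what part the fluorine of compound 1 plays.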